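Moving the Methyl on the Anilide Ring

The compounds below may be only part of what the source reports. "The series", "measured", "known", "first", "only" and "open" are said of these compounds alone.

Compound 3 `Cc1ccc(CC(=O)O)cc1NC(=O)c1ccc(OC[C@@H]2CN(C)c3ccccc3O2)cc1Cl` is one of three compounds tested in an assay on CHO cells for displacement of a labelled ligand from prostaglandin D2 receptor (Mus musculus), read by scintillation counting, with a stated time of 60 min; on this read-out lower numbers stand for stronger inhibition and higher numbers for weaker inhibition. Compound 3 gives 26 nM, the second highest of the three numbers; compound 1 `CN1C[C@@H](COc2ccc(C(=O)Nc3cccc(CC(=O)O)c3)c(Cl)c2)Oc2ccccc21` gives 16 nM in this assay, and compound 2 `Cc1cc(OC[C@@H]2CN(C)c3ccccc3O2)ccc1C(=O)Nc1cccc(CC(=O)O)c1C` gives 59 nM. Compound 4 `Cc1cc(CC(=O)O)cc(NC(=O)c2ccc(OC[C@@H]3CN(C)c4ccccc4O3)cc2Cl)c1` keeps the same atoms as compound 3 but joins them differently: 3-(carboxymethyl)-5-methylphenyl in place of 5-(carboxymethyl)-2-methylphenyl on an amide-type nitrogen. For the measured compounds named here, no measured step shows what shifting these groups around that ring does. Going by the values given here, the only single step known, a 1.6-fold higher number from compound 1 to compound 3 (0.21 log units; within the scatter), shows that adding the methyl to compound 1 changed little, so the move is expected to shift the number only modestly, if at all, leaning toward weaker binding. Compound 4 is therefore estimated at 35 nM in this assay, within 10 nM to 120 nM, a step of a 1.3-fold higher number from compound 3 to compound 4 (0.13 log units; within the scatter).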

Compound 4, inhibition constant: 12 nM
Compound 4: the middle estimate sits 2.9-fold (0.46 log units) above what was measured, within the range that was stated.
By their numbers in this assay, from the lowest: compounds 4, 1 and 3 (each within the scatter of the next, the first and the last beyond it); then compound 2.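

In this assay, putting 3-(carboxymethyl)-5-methylphenyl in place of 5-(carboxymethyl)-2-methylphenyl gives a 2.2-fold lower number from compound 3 to compound 4 (0.34 log units; beyond the scatter), so the place of the methyl on this ring can matter. Adding the methyl to compound 1 in this new place gives a 1.3-fold lower number from compound 1 to compound 4 (0.12 log units; within the scatter), so neither placement moves clearly away from the compound without it, though the two placements differ from each other. No evidence here accounts for this difference. On these data alone, whether an ethyl group or a methoxy group in place of this methyl would give a similar number remains open.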